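Trimming the amine tail from diethyl to dimethyl

The source may hold more compounds than are shown below. What is called first, only, known or untested is meant among the compounds shown, and "the series" means these compounds.

Compound 1, `CCn1c(C(=O)NCC(=O)O)ccc1C(CC)(CC)c1ccc(C#CC(O)(CC)CC)c(C)c1`, gives 85.7 nM in an assay on cells for binding affinity to vitamin D3 receptor (Homo sapiens), read by fluorescence polarization; a higher number here means a weaker inhibitor, a lower number a stronger inhibitor.
Compound 2, `CCn1c(C(=O)NCCCO)ccc1C(CC)(CC)c1ccc(C#CC(O)(CC)CC)c(C)c1`, gives 123 nM in this assay.
Compound 3, `CCN(CC)CCNC(=O)c1cc(C(CC)(CC)c2ccc(C#CC(O)(CC)CC)c(C)c2)cn1CC`, gives 56.5 nM in this assay.

Among these three numbers compound 3 stands at the low end. Its gap to compound 1 is within the usual scatter of repeated measurements, so the two cannot be told apart; its gap to compound 2 is beyond the scatter, so compound 3 does sit lower than compound 2.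

Compound 4, `CCn1cc(C(CC)(CC)c2ccc(C#CC(O)(CC)CC)c(C)c2)cc1C(=O)NCCN(C)C`, shares the core of compound 3 and differs from it in one place: dimethylamino in place of diethylamino on a saturated chain carbon, two bonds along the chain from an amide-type nitrogen. For the measured compounds named here, only one measured step exists here, a 1.4-fold higher number from compound 1 to compound 2 (0.16 log units; within the scatter), and it concerns a different change at the end of the amide chain, between compounds that lack the amine tail altogether. Going by the values given here, no measured pair speaks to the swap of one amine for a smaller one on this chain. Without a step that bears on the change, the expectation is that the number for compound 4 will stay close to that of compound 3, with no step beyond the scatter: a 1.1-fold higher number from compound 3 to compound 4 (0.03 log units; within the scatter) is expected. Compound 4 is therefore estimated at 60 nM in this assay, within a range from 30 nM to 120 nM.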

Compound 4, half-maximal inhibitory concentration: 51.3 nM
For compound 4 the middle estimate is 1.2-fold (0.07 log units) above the measured one, within the range that was stated.
By their numbers in this assay, from the lowest: compounds 4, 3, 1 and 2 (each within the scatter of the next, the first and the last beyond it).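

In this assay, for the compounds shown here, a 1.1-fold lower number from compound 3 to compound 4 (0.04 log units; within the scatter) gives the first measured reading of a change to the amine itself, and the two compounds cannot be told apart. On this core, at this place on the chain, the group can therefore go from diethylamino, with 5 heavy atoms, to dimethylamino, with 3, without a change in the number that stands beyond the scatter. Going by these compounds alone, nothing available here accounts for this result, so the data record only that the two numbers agree, not what lies behind the agreement.

On these data alone, it remains open whether the tail would read the same with a ring amine such as pyrrolidine or morpholine, with an unsubstituted amino group, or with a longer chain between the amide nitrogen and the amine. This single pair also cannot say whether the swap from diethylamino to dimethylamino would behave the same way on a different core.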